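The compounds below may be only part of what the source reports. "The series", "measured", "known", "first", "only" and "open" are said of these compounds alone.

Compound 3 `O=C(Nc1ncccc1Cl)N1CCC(c2nc(-c3ccc4ccccc4n3)no2)CC1` gives 2800 nM in a functional assay on Shh Light II cells (Mus musculus) for inhibition, read by a luciferase reporter (on this read-out lower numbers stand for stronger inhibition and higher numbers for weaker inhibition), the highest of the three numbers in hand: compound 1 `O=C(NC1CCNCC1)N1CCC(c2nc(-c3ccc4ccccc4n3)no2)CC1` gives 2500 nM and sits within the scatter of it, while compound 2 `O=C(OC1CCCCC1)N1CCC(c2nc(-c3ccc4ccccc4n3)no2)CC1` gives 580 nM and lies beyond it. Compound 4 `O=C(NC1CCCCC1)N1CCC(c2nc(-c3ccc4ccccc4n3)no2)CC1` carries cyclohexyl in place of 3-chloropyridin-2-yl on an amide-type nitrogen. Within the data shown here, two steps bear on this change. The step of a 1.1-fold higher number from compound 1 to compound 3 (0.05 log units; within the scatter) shows that swapping one group on the amide-type nitrogen for another stayed within the scatter, whereas a 4.8-fold higher number from compound 2 to compound 3 (0.68 log units; beyond the scatter) shows a modest move when the cyclohexyloxy group gave way to the (3-chloropyridin-2-yl)amino group. Compound 4 pairs the amide-type nitrogen of compound 3 with the cyclohexyl ring of compound 2. A modest lowering is therefore expected, a 2.3-fold lower number from compound 3 to compound 4 (0.37 log units; beyond the scatter). Compound 4 is estimated at 1200 nM, with a range of 500 nM to 3000 nM.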

Compound 4, half-maximal inhibitory concentration: 57 nM
Beside the measured number, compound 4's estimate is 21-fold (1.32 log units) above it, outside the stated range (below it).
By their numbers in this assay, from the lowest: compound 4; then compound 2; then compounds 1 and 3 (each within the scatter of the next).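

On the amide-type nitrogen, cyclohexyl separates clearly from the groups seen before in this assay, with a 49-fold lower number from compound 3 to compound 4 (1.69 log units; beyond the scatter) and a 44-fold lower number from compound 1 to compound 4 (1.64 log units; beyond the scatter) although 3-chloropyridin-2-yl and piperidin-4-yl had stayed within the scatter of each other. With the cyclohexyl ring kept, the atom joining it to the carbonyl carbon also counts, as cyclohexylamino in place of cyclohexyloxy gives a 10-fold lower number from compound 2 to compound 4 (1.01 log units; beyond the scatter) on this read-out. No measurement in hand explains these steps.

Going by these compounds, whether the effect needs the complete cyclohexyl ring remains open. A cyclopentyl ring, a phenyl ring or an open hexyl chain on the same nitrogen would address this.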